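Swapping One Halogen for Another on the Sulfonyl Ring

A few compounds are considered here, and "the series" means these few. Any claim that something is new, unique, unknown or untested is made for them only; others in the source may bear on it.

Compound 1 `O=S(=O)(c1cccc(F)c1)c1cn(C2CCNC2)c2ncccc12` is the reference point. For the measured compounds named here, in a functional assay on HeLa cells for agonist activity at 5-hydroxytryptamine receptor 6 (Homo sapiens), read by cAMP accumulation and immunoassay (on this read-out higher numbers stand for an effect only at larger amounts of compound and lower numbers for an effect already at smaller amounts), compound 1 gives 278 nM, the lowest of the two numbers so far. Going by the values given here, its only measured neighbour is compound 2 `O=S(=O)(c1ccc(F)cc1)c1cn(C2CCNC2)c2ncccc12`, which in this assay gives 1650 nM; the step of a 5.9-fold higher number from compound 1 to compound 2 (0.77 log units; beyond the scatter) is beyond the scatter and runs toward weaker activity. Compound 3 `O=S(=O)(c1cccc(Br)c1)c1cn(C2CCNC2)c2ncccc12` keeps the fluorophenyl pattern of compound 1 but changes the halogen: bromo in place of fluoro on an aromatic carbon. Among the compounds with values here, no measured step involves a change of halogen on this ring, so the step from compound 1 to compound 2 bears on it only indirectly, as a sign that the sulfonyl-bound ring is sensitive to what it carries. With one heavy atom traded for one heavy atom, and no change in donors, acceptors or charge, the expected step is a 1.1-fold lower number from compound 1 to compound 3 (0.05 log units; within the scatter), small and within the scatter. Compound 3 is therefore estimated at 250 nM, with a plausible range from 80 nM to 800 nM.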

Compound 3, half-maximal effective concentration: 35 nM
Estimate against measurement, compound 3: 7.1-fold (0.85 log units) above, and the stated range ends above it.
By their numbers in this assay, from the lowest: compound 3; then compound 1; then compound 2.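

Compound 1 and compound 2 showed that the place of a fluoro on the sulfonyl-bound ring matters; with the place held fixed, the identity of the halogen turns out to matter as well, and bromo in place of fluoro gives a 7.9-fold lower number from compound 1 to compound 3 (0.90 log units; beyond the scatter) in this assay on this ring. A change of halogen and a change of place taken together make up a 47-fold lower number from compound 2 to compound 3 (1.67 log units; beyond the scatter) in this assay and form the largest step seen so far. No measurement at hand gives a reason for the effect of bromo here.

The compounds shown leave open whether this gain belongs to bromo alone or would also appear with chloro, iodo, methyl or methoxy on the same carbon. They also leave open whether bromo keeps this gain on other versions of the shared core.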